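Amide replacement on the azetidine carbonyl of compound 3

The compounds below may be only part of what the source reports. "The series", "measured", "known", "first", "only" and "open" are said of these compounds alone.

Compound 3 `O=C(c1cccc(F)c1)N1CC(c2nc(-c3cccc(Cl)c3)no2)C1` carries a 3-fluorophenyl on the carbonyl carbon. In an assay on HEK293 cells for positive allosteric modulation of metabotropic glutamate receptor 5 (Homo sapiens), read by FLIPR (on this read-out lower numbers stand for an effect already at smaller amounts and higher numbers for an effect only at larger amounts of compound), compound 3 reaches only the limit > 10000 nM and gives no number. Compound 2 `O=C(c1ccc(F)cc1)N1CC(c2nc(-c3cccc(Cl)c3)no2)C1` likewise shows only the limit > 10000 nM in this assay. Compound 1 `O=C(N1CCC(F)CC1)N1CC(c2nc(-c3cccc(Cl)c3)no2)C1`, with 4-fluoropiperidin-1-yl on the same carbonyl, gives 990 nM in this assay. The steps of an at least 10-fold higher number from compound 1 to compound 2 (1.00 log units; beyond the scatter) and an at least 10-fold higher number from compound 1 to compound 3 (1.00 log units; beyond the scatter) are both beyond the scatter, and the limit of > 10000 nM in this assay, at which 2 of the 3 values shown sit, sets where compounds 2 and 3 sit. The step that the two limits leave unreadable from compound 2 to compound 3 cannot be read.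

Compound 4 `O=C(C1CCC1)N1CC(c2nc(-c3cccc(Cl)c3)no2)C1` differs from compound 3 by cyclobutyl in place of 3-fluorophenyl on a carbonyl carbon. Going by the values given here, the only measured change at this carbonyl that moved the number was the exchange of a saturated ring for an aromatic one, seen in an at least 10-fold higher number from compound 1 to compound 3 (1.00 log units; beyond the scatter); cyclobutyl is again a saturated ring, so a step back toward a readable number is expected, though its size rests on a single comparison. The step of an at least 3.3-fold lower number from compound 3 to compound 4 (0.52 log units; beyond the scatter) is therefore expected. Compound 4 is estimated at 3000 nM in this assay, within 800 nM to 10000 nM.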

Compound 4, half-maximal effective concentration: > 10000 nM
Compound 4: no number, only a limit; the forecaster's own chance of this, stated with the estimate: 35%; at least 3.3-fold (0.52 log units) between middle value and limit.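

In this assay compound 4 also gives only a limit, so a non-aromatic ring of carbon only on the carbonyl carbon does not by itself bring back a readable number. With an at least 10-fold higher number from compound 1 to compound 4 (1.00 log units; beyond the scatter) the contrast between saturated and aromatic rings no longer describes this position, and 4-fluoropiperidin-1-yl remains the only group shown that gives a number. The steps among compounds 2, 3 and 4 cannot be read, and these three compounds cannot be ranked: the limit of > 10000 nM in this assay, at which 3 of the 4 values shown sit.

Still open, from the compounds shown here alone, is whether the number of compound 1 depends on the fluorine or on attachment of the ring through its nitrogen to the carbonyl carbon. A piperidin-1-yl without fluorine, a morpholin-4-yl or a dimethylamino group on the same carbonyl would separate these two readings.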